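The source may hold more compounds than are shown below. What is called first, only, known or untested is meant among the compounds shown, and "the series" means these compounds.

The measured compounds:
compound 1 `O=C(O)c1ccc(C(=O)Nc2cc(-c3ccccc3)nn2-c2ccccc2)cc1` — in an assay on HEK293 cells for displacement of a labelled ligand from metabotropic glutamate receptor 5 (Rattus norvegicus) (on this read-out lower numbers stand for stronger inhibition and higher numbers for weaker inhibition), compound 1 gives > 10000 nM, a limit of the assay rather than a number.
compound 2 `O=C(Nc1cc(-c2ccccc2)nn1-c1ccccc1)C1=CCCCC1` — in this assay compound 2 gives 4470 nM.

Compound 2 carries the only number shown in this assay; the remaining value is a limit (the limit of > 10000 nM in this assay, at which 1 of the 2 values shown sits). Going by the values given here, the single measured step, an at least 2.2-fold lower number from compound 1 to compound 2 (0.34 log units; beyond the scatter), concerns the group on the carbonyl carbon but swaps an aromatic acid for a ring with one double bond, so it does not speak directly to the change at hand. Compound 3 `O=C(Nc1cc(-c2ccccc2)nn1-c1ccccc1)C1CCCC1` differs from compound 2 by cyclopentyl in place of cyclohex-1-en-1-yl on a carbonyl carbon. Among the compounds with values here, with no measured step covering the loss of the double bond or the move from a six-membered to a five-membered ring, the analysis expects compound 3 to remain near compound 2, the expected step of a 1.3-fold higher number from compound 2 to compound 3 (0.13 log units; within the scatter) lying within the scatter, with a wide range to reflect the uncertainty. Compound 3 is estimated at 6000 nM, between 2000 nM and 20000 nM.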

Compound 3, inhibition constant: 11600 nM
The estimate for compound 3 lay 1.9-fold (0.29 log units) below the measured number, within the range that was stated.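

On the carbonyl carbon, cyclopentyl in place of cyclohex-1-en-1-yl gives a 2.6-fold higher number from compound 2 to compound 3 (0.41 log units; beyond the scatter) in this assay, so this position responds to a change between two non-aromatic carbon rings, neither of which has a hydrogen-bond donor or acceptor. The number for compound 3 is the weaker of the two numbers available, which leaves cyclohex-1-en-1-yl as the better of these two rings here. Compound 1 stands at a limit of the assay rather than a number, so its step to compound 3 cannot be read: the limit of > 10000 nM in this assay, at which 1 of the 3 values shown sits.

The step combines the loss of the double bond with the smaller ring, and the compounds shown do not separate the two, which cyclohexyl on the same carbonyl carbon would do. On these data alone, how an open chain such as tert-butyl or a ring bearing an amine would read at this position also remains open.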